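The source may hold more compounds than are shown below. What is called first, only, known or untested is meant among the compounds shown, and "the series" means these compounds.

Measured so far in an ADME assay for permeability, using PAMPA, with a stated time of 30 min, at pH 7.4; a higher number here means that the compound crosses the layer faster, a lower number that the compound crosses the layer more slowly:
- compound 1 `c1ccc(Oc2ccc3c(NCCCNCc4ccco4)ccnc3c2)cc1` gives 317 10^-6 cm/s
- compound 2 `CCC(CC)c1ccc2c(NCCCNCc3cccc(OC)c3O)ccnc2c1` gives 23 10^-6 cm/s
- compound 3 `COc1ccc(F)cc1CNCCCNc1ccnc2cc(Cc3ccccc3)ccc12` gives 23 10^-6 cm/s

Compound 2 sits level with compound 3 at the digits shown, the two together forming the lowest pair of the three; compound 1 gives a higher number, and that gap is beyond the scatter. Compound 4 `COc1cccc(CNCCCNc2ccnc3cc(-c4cccc5ccccc45)ccc23)c1O` differs from compound 2 as follows: naphthalen-1-yl in place of pentan-3-yl on an aromatic carbon. Among the measured compounds shown here, no step between measured compounds isolates such a change, so the expectation rests on the standing of compound 2 alone. For compound 4 the expected step of a 1.3-fold higher number from compound 2 to compound 4 (0.12 log units; within the scatter) is small, most likely not beyond the scatter, with a modest rise possible. Compound 4 is therefore estimated at 30 10^-6 cm/s, in the range 10 10^-6 cm/s to 90 10^-6 cm/s.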

Compound 4, apparent permeability: 237 10^-6 cm/s
The estimate for compound 4 lay 7.9-fold (0.90 log units) below the measured number, and the stated range ends below it.
By their numbers in this assay, from the lowest: compounds 2 and 3 (each within the scatter of the next); then compounds 4 and 1 (each within the scatter of the next).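

In this assay, naphthalen-1-yl in place of pentan-3-yl on an aromatic carbon gives a 10-fold higher number from compound 2 to compound 4 (1.01 log units; beyond the scatter). Among the compounds shown here, this is the first single-place change, and it shows that the read-out responds strongly to the group at this position of the shared core. No measurement at hand bears on the reason for the step.

The compounds shown leave open whether the step follows the aromatic rings or the larger group. A single phenyl ring, a longer alkyl chain or an amine at this position would help separate the two.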